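Halogen swap on the aryl ketone of the pyrazolyl series

This account rests on a few compounds, and the source may have more. Where it says the series, first, only, none or still open, it means among the compounds named here.

Three compounds of this series carry a measured number in a functional assay on SK-MEL-2 cells (Homo sapiens) for inhibition, read by sulforhodamine B assay, with a stated time of 48 h; a lower number here means a stronger inhibitor of growth, a higher number a weaker inhibitor of growth. Compound 1 `COc1cc(-c2cc(/C=C/C(=O)c3ccc(Cl)c(Cl)c3)[nH]n2)cc(OC)c1OC` gives 34100 nM, the highest of the three. Compound 2 `COc1ccc(-c2cc(/C=C/C(=O)c3ccc(N)cc3)[nH]n2)cc1OC` gives 22200 nM, which sits within the scatter of compound 1, so no order between these two can be drawn. Compound 3 `COc1ccc(-c2cc(/C=C/C(=O)c3cc(OC)c(OC)c(OC)c3)[nH]n2)cc1OC` gives 7700 nM, a gap to compound 1 that lies beyond the scatter. Within the data shown here, no pair among the measured compounds differs in one place, so no single step has been characterised.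

Compound 4 `COc1cc(-c2cc(/C=C/C(=O)c3ccc(F)c(F)c3)[nH]n2)cc(OC)c1OC` has not yet been measured. It differs from compound 1 in one place: 3,4-difluorophenyl in place of 3,4-dichlorophenyl on a carbonyl carbon. The two chlorine atoms give way to two fluorine atoms at the same ring positions, with nothing else altered. Among the measured compounds shown here, no measured pair shows what such an exchange does here, so the step is expected to be small, with no clear direction beyond the scatter. The estimate for compound 4 in this assay is 30000 nM, with a range from 12000 nM to 80000 nM, which means an expected step of a 1.1-fold lower number from compound 1 to compound 4 (0.06 log units; within the scatter).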

Compound 4, concentration for total growth inhibition: 5890 nM
Estimate against measurement, compound 4: 5.1-fold (0.71 log units) above; the measured number lies below the stated range.
By their numbers in this assay, from the lowest: compounds 4 and 3 (each within the scatter of the next); then compounds 2 and 1 (each within the scatter of the next).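

In this assay, among these compounds, this is the first single step characterised: 3,4-difluorophenyl in place of 3,4-dichlorophenyl on a carbonyl carbon gives a 5.8-fold lower number from compound 1 to compound 4 (0.76 log units; beyond the scatter), beyond the scatter. The position therefore responds to a change of halogen alone, although the two groups match in heavy-atom count, aromatic ring, hydrogen-bond donors and acceptors, and net charge. No measurement available here accounts for the step.

From the compounds shown here alone, it remains open whether a 3,4-dibromophenyl or an unsubstituted phenyl on the same carbonyl carbon would follow the fluorine or the chlorine compound. Also unsettled is whether the same exchange gives a step of similar size and direction on the core of compound 3.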